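This account rests on a few compounds, and the source may have more. Where it says the series, first, only, none or still open, it means among the compounds named here.

Measured so far, all in an ADME assay on HEK293 cells (Homo sapiens) for cytotoxicity, read by luminescence, with a stated time of 72 h; a higher number here means that more compound is needed for the effect, a lower number that less compound is needed:
- Compound 1, `CCOC(=O)c1c(-c2ccccc2)[nH]c2cc(OC)ccc2c1=O`: this assay reports only a limit, > 22000 nM.
- Compound 2, `CCOC(=O)c1c(-c2cccc(C)c2)[nH]c2cc(OC)ccc2c1=O`: again only a limit, > 22000 nM.
- Compound 3, `CCCOc1cccc(-c2[nH]c3cc(OC)ccc3c(=O)c2C(=O)OCC)c1`: again only a limit, > 22000 nM.

Compound 1 stands at no number at all, only at the limit of > 22000 nM in this assay, at which 3 of the 3 values shown sit. Compound 4, `CCOC(=O)c1c(-c2cccc(Br)c2)[nH]c2cc(OC)ccc2c1=O`, differs from it by bromo in place of hydrogen on an aromatic carbon. The two measured steps that start from compound 1 are a step that the two limits leave unreadable from compound 1 to compound 2 and a step that the two limits leave unreadable from compound 1 to compound 3; both run between limits, so neither gives a size or a direction. With no readable step behind it, no step beyond the scatter is expected from compound 1 to compound 4, and the likeliest outcome is that this assay again stops at its limit. Compound 4 is therefore estimated at 22000 nM, range 10000 nM to 60000 nM. The expected step is a number no higher from compound 1 to compound 4 (the limit leaves the size open).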

Compound 4, half-maximal effective concentration: > 22000 nM
Compound 4: no number, only a limit; the forecaster's own chance of this, stated with the estimate: 80%; the middle value lies on the limit itself.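

Compound 4 gives only a limit, as do compound 1, compound 2 and compound 3, so no step to compound 4 can be read: the limit of > 22000 nM in this assay, at which 4 of the 4 values shown sit.

The compounds shown leave open what number any of the four would reach, and whether methyl, propoxy or bromo in place of hydrogen shifts it at all.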